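The source may report more compounds than this note shows. Statements on the series, on what has been measured and on what is new or still open speak of the compounds shown alone.

Measured compounds in a functional assay on NCI-H23 cells (Homo sapiens) for cytotoxicity, read by sulforhodamine B assay, with a stated time of 72 h; a lower number here means a stronger inhibitor of growth, a higher number a weaker inhibitor of growth:
compound 1 `O=C(Nc1ccccc1C(F)(F)F)C1CCc2ccccc2N1C(=O)c1ccccc1`: 6340 nM
compound 2 `O=C(Nc1cc(C(F)(F)F)cc(C(F)(F)F)c1)C1CCc2ccccc2N1C(=O)c1ccc(Cl)cc1`: 889 nM
compound 3 `O=C(Nc1ccccc1O)C1CCc2ccccc2N1C(=O)c1ccccc1`: 3490 nM

Compound 3 stands second highest of the three numbers. Its nearest neighbour is compound 1, from which it differs by hydroxy in place of trifluoromethyl on an aromatic carbon; the step is a 1.8-fold lower number from compound 1 to compound 3 (0.26 log units; within the scatter). Among the measured compounds shown here, compound 2 gives the lowest number; no single step connects it to compound 3, and it differs both in the groups on the anilide ring and by carrying a chloro on the benzoyl ring.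

Compound 4 `O=C(Nc1ccccc1O)C1CCc2ccccc2N1C(=O)c1cccc(Cl)c1` differs from compound 3 by chloro in place of hydrogen on an aromatic carbon. For the measured compounds named here, no measured step isolates this change. Going by the values given here, the only hint is that compound 2, which also carries a chloro, gives 889 nM against 3490 nM for compound 3, but that comparison mixes several changes. A small lowering of the number is therefore expected for compound 4, a 1.7-fold lower number from compound 3 to compound 4 (0.24 log units; within the scatter), with wide uncertainty. Compound 4 is estimated at 2000 nM, within 700 nM to 5500 nM.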

Compound 4, concentration for 50% growth inhibition: 11600 nM
Estimate against measurement, compound 4: 5.8-fold (0.76 log units) below; measured number outside the range, above it.
By their numbers in this assay, from the lowest: compound 2; then compounds 3, 1 and 4 (each within the scatter of the next, the first and the last beyond it).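

In this assay, chloro in place of hydrogen on the benzoyl ring, at a carbon meta to a large group, can now be read as a single change, and it moves toward weaker growth inhibition: a 3.3-fold higher number from compound 3 to compound 4 (0.52 log units; beyond the scatter). Carrying a chloro on this ring therefore does not by itself go with a lower number, and compound 2, at 889 nM, differs from compound 3 in more than one place, so it cannot show what the chloro contributes. No measurement available here accounts for the step.

On these data alone, it remains open whether the same change gives a similar step when trifluoromethyl replaces hydroxy on the anilide ring. Also open, as far as these compounds go, is how an amine, a methoxy or a carboxylic acid at this position would compare with chloro.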